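Replacing isopropyl with methylsulfanyl in compound 1

The source may hold more compounds than are shown below. What is called first, only, known or untested is meant among the compounds shown, and "the series" means these compounds.

Among the compounds with values here, in a functional assay on SK-MEL-5 cells (Homo sapiens) for cytotoxicity (a higher number here means that more compound is needed for the effect, a lower number that less compound is needed), compound 1 `COc1cc(/C=C/c2ccc(C(C)C)cc2)cc(OC)c1OC` gives 11.1 uM, the highest number of the three measured so far. Compound 2 `COc1cc(/C=C\c2ccc(C(C)C)cc2)cc(OC)c1OC` gives 4.7 uM, and compound 3 `COc1ccc(/C=C\c2cc(OC)c(OC(C)=O)c(OC)c2)cc1` gives 0.6 uM. The next structure, compound 4 `COc1cc(/C=C/c2ccc(SC)cc2)cc(OC)c1OC`, keeps the double bond of compound 1 as drawn but exchanges one group: methylsulfanyl in place of isopropyl on an aromatic carbon. The methylsulfanyl group thus takes the place of isopropyl on an aromatic carbon. Within the data shown here, only one single-change step has been measured, a 2.4-fold lower number from compound 1 to compound 2 (0.37 log units; beyond the scatter), and it is modest. That step reflects (the fact that compounds 1 and 2 differ only in the configuration as drawn), so it gives only a rough sense of scale here. Among the measured compounds shown here, no measured pair exchanges the isopropyl group, and compound 3 at 0.6 uM differs from compound 1 in more than one place. The data therefore indicate no clear direction, and no step beyond the scatter is expected in this assay. The expected change is a 1.4-fold lower number from compound 1 to compound 4 (0.14 log units; within the scatter). Compound 4 is estimated at 8 uM, with an expected range of 2.5 uM to 25 uM.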

Compound 4, concentration for half-maximal effect: 2.8 uM
Beside the measured number, compound 4's estimate is 2.9-fold (0.46 log units) above it; low and high end bracket the measured number.
By their numbers in this assay, from the lowest: compound 3; then compounds 4 and 2 (each within the scatter of the next); then compound 1.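

In this assay there is a 4.0-fold lower number from compound 1 to compound 4 (0.60 log units; beyond the scatter) with methylsulfanyl in place of isopropyl, so the number responds to the group on this aromatic carbon, para to a large group. Within the data shown here, the earlier compounds could not show this, as their only single-change step concerned the double bond rather than this substituent. The double bond stays as drawn in compound 1, so this step belongs to the exchange of the group alone, although nothing in the data explains why the number falls.

From the compounds shown here alone, whether the sulfur atom matters or any group other than isopropyl would give a similar step remains open, as an ethyl group, an amine or a longer chain such as butylsulfanyl could tell. Going by these compounds, it is also open whether the same exchange would give a step of similar size with the double bond drawn Z.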